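The source may hold more compounds than are shown below. What is called first, only, known or untested is meant among the compounds shown, and "the series" means these compounds.

Compound 1 `O=C(O)[C@@H]1NC[C@@H](O)[C@@H](O)[C@H]1O`, compound 2 `O=C(O)[C@H]1NC[C@@H](O)[C@@H](O)[C@@H]1O` and compound 3 `O=C(O)[C@@H]1NC[C@@H](O)[C@@H](O)[C@@H]1O` share the same atoms and bonds and differ only in the configuration drawn at their saturated ring carbons, as the facts (the fact that compounds 1 and 2 differ only in the configuration as drawn), the fact that compounds 1 and 3 differ only in the configuration as drawn and the fact that compounds 2 and 3 differ only in the configuration as drawn record. In an assay for inhibition of alpha-N-acetylgalactosaminidase (Gallus gallus), tested at 1000 uM (on this read-out lower numbers stand for less inhibition and higher numbers for more inhibition at the one concentration tested (going by the name of the read-out)), compound 1 gives 8.2%, compound 2 gives 3.8% and compound 3 gives 7.2%. Compound 3 thus sits among three numbers that all lie within the scatter of one another: the step of a number 1 percentage points lower from compound 1 to compound 3 (within the scatter) and the step of a number 3.4 percentage points higher from compound 2 to compound 3 (within the scatter) are each inside it, as is the step of a number 4.4 percentage points lower from compound 1 to compound 2 (within the scatter), so no order can be read among the three.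

Compound 4 `O=C(O)[C@@H]1NC[C@H](O)[C@@H](O)[C@@H]1O` continues this series by a further change of configuration only: the two compounds have the same atoms and bonds and differ only in configuration as drawn: 1 of 4 stereo elements differ; a stereocentre at a saturated ring carbon is drawn R in compound 3 and S in compound 4. The three measured steps that bear on it are all of the same kind, a swap of drawn configuration at one or two saturated ring carbons, and none of them moved the number beyond the scatter. From this he expects the step of a number 0.7 percentage points lower from compound 3 to compound 4 (within the scatter) to be no larger than the scatter, in no particular direction. He therefore estimates for compound 4 a value of 6.5% in this assay, with a range from 0% to 15%.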

Compound 4, a percentage reported as inhibition, at one concentration (the size of the read-out at that concentration, not a potency): 3.4%
For compound 4 the middle estimate is 3.1 percentage points above the measured one; low and high end bracket the measured number.
By their numbers in this assay, from the lowest: compounds 4, 2, 3 and 1 (each within the scatter of the next).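

Inverting this saturated ring carbon, a stereocentre that none of the earlier steps had changed, gives a number 3.8 percentage points lower from compound 3 to compound 4 (within the scatter), so in this assay this centre, like the others changed so far, shows no difference that can be told from the scatter: the fact that compounds 3 and 4 differ only in the configuration as drawn. The two comparisons that change two stereocentres at once, a number 0.4 percentage points lower from compound 2 to compound 4 (within the scatter) and a number 4.8 percentage points lower from compound 1 to compound 4 (within the scatter), also stay inside the scatter, so the new compound adds no order to the series. Across these four compounds, then, changing the drawn configuration at any of the three stereocentres varied so far has given no step beyond the scatter in this assay, whether one stereocentre changes or two.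

On these data alone, the fourth stereocentre is drawn alike in all four compounds, so what its inversion would do remains open. All four compounds also keep the carboxylic acid and the hydroxyl groups, which leaves open whether an amide or a hydroxymethyl group in place of the carboxylic acid would give a number beyond the scatter.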